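The source may hold more compounds than are shown below. What is called first, only, known or untested is meant among the compounds shown, and "the series" means these compounds.

Measured in a functional assay on PC-3 cells (Homo sapiens) for cytotoxicity, read by MTT assay, with a stated time of 48 h; a higher number here means a weaker inhibitor, a lower number a stronger inhibitor:
compound 1 `COc1cc(-c2nnc3n2NC(c2cccs2)C(C(=O)c2ccc(C)cc2)S3)cc(OC)c1OC` gives 5090 nM.
compound 2 `COc1ccc(C(=O)C2Sc3nnc(-c4cc(OC)c(OC)c(OC)c4)n3NC2c2ccco2)cc1` gives only a limit, > 100000 nM.
compound 3 `COc1cc(-c2nnc3n2NC(c2ccco2)C(C(=O)c2ccc(C)cc2)S3)cc(OC)c1OC` gives 7500 nM.

Compound 1 holds the lowest of the two numbers in this assay; the step of a 1.5-fold higher number from compound 1 to compound 3 (0.17 log units; within the scatter) stays within the scatter. Compound 4 `COc1cc(C(=O)C2Sc3nnc(-c4cc(OC)c(OC)c(OC)c4)n3NC2c2cccs2)cc(OC)c1OC` is not yet measured. It differs from compound 1 by 3,4,5-trimethoxyphenyl in place of 4-methylphenyl on a carbonyl carbon.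

Within the data shown here, the one measured step that bears on this change is an at least 13-fold lower number from compound 2 to compound 3 (1.12 log units; beyond the scatter): methyl in place of methoxy on an aromatic carbon brings the number down from a limit (the limit of > 100000 nM in this assay, at which 1 of the 3 values shown sits) to a number. Compound 4 moves the other way, 3,4,5-trimethoxyphenyl in place of 4-methylphenyl, so a step upward in this assay beyond the scatter is expected, a 9.8-fold higher number from compound 1 to compound 4 (0.99 log units; beyond the scatter). Compound 4 is estimated at 50000 nM, between 10000 nM and 250000 nM, with a real chance that only a limit is returned.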

Compound 4, half-maximal inhibitory concentration: > 100000 nM
Compound 4 gave a limit, no number; the forecaster's own chance of this, stated with the estimate: 40%; middle value at least 2.0-fold (0.30 log units) away from the limit.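

In this assay, an at least 19-fold higher number from compound 1 to compound 4 (1.29 log units; beyond the scatter), so the group on the carbonyl carbon also matters with thiophen-2-yl on the saturated ring carbon, not only with furan-2-yl as in an at least 13-fold lower number from compound 2 to compound 3 (1.12 log units; beyond the scatter). As far as these compounds go, compound 4 returns a limit, > 100000 nM, and the true size of its step stays unknown. Both methoxy-bearing aryl groups shown on this carbonyl carbon sit at the limit, and no compound shown goes against this: the limit of > 100000 nM in this assay, at which 2 of the 4 values shown sit.

Only 4-methylphenyl on this carbon gives numbers here. Open, from the compounds shown here alone, is whether a 4-chlorophenyl or a 4-aminophenyl there would also return a number.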